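The compounds below may be only part of what the source reports. "The series", "measured", "known", "first", "only" and "open" are said of these compounds alone.

Measured in a functional assay on A549 cells (Homo sapiens) for inhibition, read by CCK-8 assay, with a stated time of 48 h; a higher number here means a weaker inhibitor, a lower number a stronger inhibitor:
compound 1 `COc1cc(-c2ccnc3cc(-c4ccc(C)cc4)nn23)cc(OC)c1OC` gives 3 nM;
compound 2 `COc1cc(-c2ccnc3cc(-c4ccc(-c5cnn(C)c5)cc4)nn23)cc(OC)c1OC` gives 1150 nM;
compound 3 `COc1cc(-c2ccnc3cc(-c4cn(C)c5ccccc45)nn23)cc(OC)c1OC` gives 1340 nM.

Compound 3 has the highest number of the three: compound 2 sits within the scatter of it, while compound 1 lies far lower. Compound 4 `COc1cc(-c2ccnc3cc(-c4ccc(C(F)(F)F)cc4)nn23)cc(OC)c1OC` follows from compound 3 by one change: 4-(trifluoromethyl)phenyl in place of 1-methyl-1H-indol-3-yl on an aromatic carbon. Among the compounds with values here, two measured steps bear on this change, a 450-fold higher number from compound 1 to compound 3 (2.65 log units; beyond the scatter) and a 380-fold higher number from compound 1 to compound 2 (2.58 log units; beyond the scatter), both large. Compound 4 again carries a phenyl ring bearing one group, the arrangement found in compound 1 at 3 nM. A large downward step is therefore expected, a 130-fold lower number from compound 3 to compound 4 (2.13 log units; beyond the scatter). Compound 4 is estimated at 10 nM, with a range from 2 nM to 60 nM.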

Compound 4, half-maximal inhibitory concentration: 2070 nM
For compound 4 the middle estimate is 210-fold (2.32 log units) below the measured one, outside the stated range (above it).
By their numbers in this assay, from the lowest: compound 1; then compounds 2, 3 and 4 (each within the scatter of the next).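

Keeping a phenyl ring with one group at this position is not enough: trifluoromethyl in place of methyl brings a 690-fold higher number from compound 1 to compound 4 (2.84 log units; beyond the scatter) and so loses the low number of compound 1. Within the data shown here, compound 4 also joins the two weak compounds, with a 1.5-fold higher number from compound 3 to compound 4 (0.19 log units; within the scatter) and a 1.8-fold higher number from compound 2 to compound 4 (0.26 log units; within the scatter) showing no separation, although its ring resembles the one in compound 1. No measurement shown accounts for this loss.

From the compounds shown here alone, it remains open whether methyl alone keeps the low number. Ethyl, chlorine or methoxy in its place could show how narrow this requirement is.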